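The source may hold more compounds than are shown below. What is called first, only, known or untested is meant among the compounds shown, and "the series" means these compounds.

Working notes on three compounds with the shared core, read in a functional assay on SMMC-7721 cells (Homo sapiens) for cytotoxicity, read by MTT assay, with a stated time of 24 h; on this read-out lower numbers stand for stronger inhibition and higher numbers for weaker inhibition. Compound 1 `CC(=O)Nc1ccc(S(=O)(=O)N2C/C(=C\c3cccnc3)C(=O)/C(=C/c3ccccc3F)C2)cc1` gives 10900 nM. Compound 2 `O=C1/C(=C/c2ccncc2)CN(S(=O)(=O)c2ccc(F)cc2)C/C1=C\c1ccccc1F` stands at > 20000 nM, which is a limit of the assay and not a number. Compound 3 `CC(=O)Nc1ccc(S(=O)(=O)N2C/C(=C\c3ccncc3)C(=O)/C(=C/c3ccccc3F)C2)cc1` has not yet been measured. It differs from compound 2 by acetamido in place of fluoro on an aromatic carbon, with acetamido in place of fluoro on an aromatic carbon, para to a large group: 4-fluorophenyl to 4-acetamidophenyl. Among the compounds with values here, no measured step isolates this change, so its size in this assay can only be judged indirectly. Compound 1 also carries the 4-acetamidophenyl group and gives 10900 nM, so a modest move towards stronger inhibition is expected. The expected change is an at least 2.0-fold lower number from compound 2 to compound 3 (0.30 log units; that floor lies within the scatter). The estimate for compound 3 is 10000 nM, with an expected range of 4500 nM to 20000 nM.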

Compound 3, half-maximal inhibitory concentration: 13400 nM
Compound 3: middle estimate off by 1.3-fold (0.13 log units), on the low side, within the range that was stated.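

Within the data shown here, the change from 4-fluorophenyl to 4-acetamidophenyl now has a direct step in this assay with an at least 1.4-fold lower number from compound 2 to compound 3 (0.17 log units; that floor lies within the scatter) as its only reading, so a real gain from the acetamido group is not established. On these data alone, compound 2 stands at a limit of the assay and not at a number, so the true size of this step stays open: the limit of > 20000 nM in this assay, at which 1 of the 3 values shown sits. With the 4-acetamidophenyl group held constant, pyridin-4-yl in place of pyridin-3-yl gives a 1.2-fold higher number from compound 1 to compound 3 (0.09 log units; within the scatter) and the two pyridine attachments cannot be told apart in this series.

As far as these compounds go, whether an amine or a longer amide chain on the same aromatic carbon would move the number beyond the scatter remains open. Also open, from the compounds shown here alone, is whether the pyridine attachment matters alongside the 4-fluorophenyl group.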